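Replacing fluoro with trifluoromethoxy under growth inhibition

The source may report more compounds than this note shows. Statements on the series, on what has been measured and on what is new or still open speak of the compounds shown alone.

Measured in a functional assay on COLO 205 cells (Homo sapiens) for inhibition, read by sulforhodamine B assay; a higher number here means a weaker inhibitor of growth, a lower number a stronger inhibitor of growth:
- compound 1 `Cc1ccc2[nH]c(-c3ccc(-c4ccc(-c5ccc(N(C)C)cc5)cc4)cc3)nc2c1`: 9210 nM
- compound 2 `COc1ccc(-c2ccc(-c3ccc(-c4nc5cc(C)ccc5[nH]4)cc3)cc2)cc1OC`: 2320 nM
- compound 3 `Fc1ccc(-c2ccc(-c3ccc(-c4nc5ccccc5[nH]4)cc3)cc2)cc1`: 100000 nM

Of these three, compound 3 has the highest number, 100000 nM, and is the weakest inhibitor of growth. Compound 4 `FC(F)(F)Oc1ccc(-c2ccc(-c3ccc(-c4nc5ccccc5[nH]4)cc3)cc2)cc1` differs from compound 3 by one change: trifluoromethoxy in place of fluoro on an aromatic carbon. Within the data shown here, the only measured step, a 4.0-fold lower number from compound 1 to compound 2 (0.60 log units; beyond the scatter), has 3,4-dimethoxyphenyl in place of 4-(dimethylamino)phenyl on an aromatic carbon. It involves other groups and does not start from compound 3, so it offers only loose guidance. With compound 3 at the top of the measured numbers, a move toward stronger inhibition seems more likely than a further rise. The expected change is a 5.0-fold lower number from compound 3 to compound 4 (0.70 log units; beyond the scatter). The estimate for compound 4 is 20000 nM, with an expected range of 4000 nM to 100000 nM.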

Compound 4, concentration for 50% growth inhibition: 100000 nM
Beside the measured number, compound 4's estimate is 5.0-fold (0.70 log units) below it; the range from low to high includes it.
By their numbers in this assay, from the lowest: compound 2; then compound 1; then compounds 3 and 4 (each within the scatter of the next).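

In this assay, trifluoromethoxy in place of fluoro on an aromatic carbon, para to a large group, gives no change at the digits printed from compound 3 to compound 4 (within the scatter). A group of five heavy atoms with one hydrogen-bond acceptor and a single fluorine therefore cannot be told apart at this position in this assay. Nothing measured here accounts for this result.

Going by these compounds, whether an amine or a carboxylic acid at this position would separate from compound 3 remains open. So does whether fluoro and trifluoromethoxy would also match on the core of compound 2.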